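The compounds below may be only part of what the source reports. "The series", "measured", "known", "first", "only" and "open" are said of these compounds alone.

Measured compounds:
- Compound 1 `COc1ccc(-n2c(=O)c(C(=O)Nc3ccc(Oc4ccnc5c4ccn5C)c(F)c3)cc3cccnc32)cc1`: "not determined" (no result reported).
- Compound 2 `Cn1ccc2c(Oc3ccc(NC(=O)c4cc5cccnc5n(-c5ccc(Br)cc5F)c4=O)cc3F)ccnc21`: 6470 nM.

Two compounds share the same core, but only one of them carries a number. In a functional assay on U-87MG ATCC cells for antiproliferative activity against U-87 MG (Homo sapiens), read by MTT assay, with a stated time of 72 h (on this read-out higher numbers stand for weaker inhibition and lower numbers for stronger inhibition), compound 2 gives 6470 nM. Compound 1 was run in no assay with a reported outcome, so compound 2 stands alone: it is the only number shown, with one further entry that has no single number beside it. Among the compounds with values here, no step between two measured compounds can therefore be described.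

Compound 3 `Cn1ccc2c(Oc3ccc(NC(=O)c4cc5cccnc5n(-c5ccc(C(F)(F)F)cc5Cl)c4=O)cc3F)ccnc21` is the next compound, not yet tested in this assay. It differs from compound 2 in one place: 2-chloro-4-(trifluoromethyl)phenyl in place of 4-bromo-2-fluorophenyl on an aromatic nitrogen.

Within the data shown here, with no measured pair to lean on, the expectation rests on compound 2 alone, and the step from compound 2 to compound 3 is expected to be small, most likely none beyond the usual scatter, as a 1.2-fold lower number from compound 2 to compound 3 (0.07 log units; within the scatter) expresses. Compound 3 is thus estimated at 5500 nM in this assay, with a range from 1500 nM to 20000 nM.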

Compound 3, half-maximal inhibitory concentration: 10200 nM
Compound 3: middle estimate off by 1.9-fold (0.27 log units), on the low side; measured number inside the range.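

Compound 2 and compound 3 differ only in the aryl group on the aromatic nitrogen, and in this assay the exchange of 4-bromo-2-fluorophenyl for 2-chloro-4-(trifluoromethyl)phenyl gives a 1.6-fold higher number from compound 2 to compound 3 (0.20 log units; within the scatter) and so leaves the two compounds indistinguishable on this read-out. This first readable step shows that at this position a group of 11 heavy atoms can stand in place of one of 8, with a different halogen pattern on the ring, without a change beyond the scatter, and both compounds remain in the same micromolar range. No measured property is available to explain this result.

With a single step, the compounds shown leave open whether any group on this nitrogen can move the number beyond the scatter, and the two aryl groups read here both carry only halogen or trifluoromethyl substituents. A phenyl ring bearing an amine or a carboxylic acid, or a longer alkyl chain in place of the aryl ring, would test this position in ways these two compounds cannot.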